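The source may hold more compounds than are shown below. What is called first, only, known or untested is meant among the compounds shown, and "the series" means these compounds.

Measured compounds:
Compound 1, `CC1CCN(c2nc(C(F)(F)F)ccc2CNC(=O)Nc2cccc3c(=O)[nH]ccc23)CC1`, in an assay on CHO cells for agonist activity at transient receptor potential cation channel subfamily V member 1 (Homo sapiens) (a higher number here means that more compound is needed for the effect, a lower number that less compound is needed), compound 1 gives 9.59 nM.
Compound 2, `CC1CCN(c2nc(C(F)(F)F)ccc2CNC(=O)Nc2cccc3c2ccc(=O)n3C)CC1`, in this assay compound 2 gives "not active" (no number reported).
Compound 3, `O=C(NCc1ccc(C(F)(F)F)nc1N1CCCCC1)Nc1cccc2c(=O)[nH]ccc12`, in this assay compound 3 gives 13.2 nM.

Compound 3 holds the higher of the two reported numbers, yet its gap to compound 1 is small: the step of a 1.4-fold higher number from compound 1 to compound 3 (0.14 log units; within the scatter) lies within the usual scatter, so the two compounds cannot be told apart. Compound 2 stands apart with no number at all.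

Compound 4, `O=C(NCc1ccc(C(F)(F)F)nc1N1CCC(Cc2ccccc2)CC1)Nc1cccc2c(=O)[nH]ccc12`, is not yet measured. It differs from compound 3 in one place: benzyl in place of hydrogen on a saturated ring carbon. Going by the values given here, the only measured step that touches this position is the one from compound 1 to compound 3, where a methyl on the same saturated ring carbon made no difference beyond the scatter. Among the compounds with values here, a benzyl is a much larger group than a methyl, so that step is only a weak guide, and no other step bears on it. The expected outcome for compound 4 is therefore a step of a 1.1-fold higher number from compound 3 to compound 4 (0.06 log units; within the scatter) that stays near compound 3, with a wide range to allow for the larger group. Compound 4 is estimated at 15 nM, within 4 nM to 80 nM.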

Compound 4, half-maximal effective concentration: 5.81 nM
For compound 4 the middle estimate is 2.6-fold (0.41 log units) above the measured one; the range from low to high includes it.
By their numbers in this assay, from the lowest: compounds 4, 1 and 3 (each within the scatter of the next, the first and the last beyond it).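

In this assay, going by these compounds alone, this saturated ring carbon, three ring bonds from the ring nitrogen, takes a group far larger than methyl with no loss: the step of a 2.3-fold lower number from compound 3 to compound 4 (0.36 log units; beyond the scatter) goes beyond the scatter, though only modestly, and it is the first change here at this position that does so. Set against the methyl compound, the step of a 1.7-fold lower number from compound 1 to compound 4 (0.22 log units; within the scatter) stays within the scatter, so adding phenyl to that methyl gives a result that cannot be told apart from no change. No measurement at hand explains the shift seen with benzyl.

From the compounds shown here alone, it remains open whether a longer chain ending in phenyl, or an amine or a carboxylic acid on this carbon, would give a similar number. Also open, going by these compounds, is whether benzyl would give any number on the core of compound 2.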